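The source may report more compounds than this note shows. Statements on the series, on what has been measured and on what is new or still open speak of the compounds shown alone.

Working notes on the series.

Compound 1 `COc1ccc(C2N=C(SCc3ccccc3)NC(C)=C2C(=O)Nc2ccc(Br)cc2)cc1` carries an unsubstituted benzylsulfanyl group. In a functional assay on the whole organism (artery, strain albino) with Rattus norvegicus as the target, with a stated time of 600 min, at a dose of 10 mg/kg by the oral route (on this read-out lower numbers stand for less inhibition and higher numbers for more inhibition at the one dose given (going by the name of the read-out)), compound 1 gives 11.3%. Compound 2 `COc1ccc(C2N=C(SCc3ccc(Cl)cc3)NC(C)=C2C(=O)Nc2ccc(Br)cc2)cc1` differs from it by chloro in place of hydrogen on an aromatic carbon, and in this assay compound 2 gives 30.3%. Among the compounds with values here, the resulting step, a number 19 percentage points higher from compound 1 to compound 2 (beyond the scatter), is the only step that can be read directly.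

Compound 3 `CC1=C(C(=O)Nc2ccc([N+](=O)[O-])cc2)C(c2ccc(Br)cc2)N=C(SCc2ccccc2)N1` rests on a different core; the difference between the core of compound 3 and the core of compound 1 is not broken down here. In this assay compound 3 gives 27.2%, which sits close to the number of compound 2 and clearly higher than the number of compound 1.

Compound 4 `CC1=C(C(=O)Nc2ccc([N+](=O)[O-])cc2)C(c2ccc(Br)cc2)N=C(SCc2ccccc2Cl)N1` is not yet measured. It differs from compound 3 by chloro in place of hydrogen on an aromatic carbon. Within the data shown here, this is the same kind of change as the one from compound 1 to compound 2, but not the same: in compound 2 the chloro sits para to a large group, whereas in compound 4 it sits ortho to a large group. Because the change from compound 1 to compound 2 made the step of a number 19 percentage points higher from compound 1 to compound 2 (beyond the scatter), a rise is expected here as well, but with the chloro in another place its size is uncertain, and a smaller step, a number 8.8 percentage points higher from compound 3 to compound 4 (within the scatter), is expected. On that basis compound 4 is estimated to give 36%, with the likely range running from 20% to 52%.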

Compound 4, a percentage reported as inhibition, in the whole organism at one dose (the size of the read-out at that dose, not a potency): 9.7%
The estimate for compound 4 lay 26.3 percentage points above the measured number, and the stated range ends above it.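

On the core of compound 3, chloro in place of hydrogen gives a number 17.5 percentage points lower from compound 3 to compound 4 (beyond the scatter), the opposite direction to the earlier step on the core of compound 1. In this assay, this change therefore does not carry over from one core to the other as a fixed rise, and its direction cannot be transferred between these two cores: the same change on two cores in this assay, a number 19 percentage points higher (beyond the scatter) from compound 1 to compound 2 and a number 17.5 percentage points lower (beyond the scatter) from compound 3 to compound 4, 36.5 percentage points apart, beyond the scatter of two such steps

This does not show that the core alone sets the direction, as the two steps differ in the place of the chloro as well: in compound 4 it is the 2-chlorobenzyl group, ortho to a large group, while in compound 2 the chloro sits elsewhere, so core and place change together and one pair on each core cannot separate them.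

Still open, on these data alone, is how the 2-chlorobenzyl group reads on the core of compound 1, and how the chloro placed as in compound 2 reads on the core of compound 3. Also open, as far as these compounds go, is what an amine or a carboxylic acid on the benzyl group, or a longer chain in place of benzyl on the sulfur, would give in this assay.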